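The source may report more compounds than this note shows. Statements on the series, on what has been measured and on what is new or still open speak of the compounds shown alone.

Compound 2 `CN(C)c1ccc(C2C(C#N)=C(N)OC(c3c[nH]c4ccccc34)=C2C#N)cc1` carries a dimethylamino group on its pendant aromatic ring; in a functional assay, tested at 200 ug/mL (on this read-out higher numbers stand for a stronger effect at the one concentration tested and lower numbers for a weaker effect), compound 2 gives 20.5%. Its two measured neighbours sit close by: compound 1 `N#CC1=C(N)OC(c2c[nH]c3ccccc23)=C(C#N)C1c1ccc(F)cc1` gives 22.4% and compound 3 `COc1cc(Br)c(C2C(C#N)=C(N)OC(c3c[nH]c4ccccc34)=C2C#N)cc1OC` gives 24.2%, so the three numbers fall within the usual scatter of one another and no ordering among them can be read from this assay. Compound 4 `Cc1ccc(C2C(C#N)=C(N)OC(c3c[nH]c4ccccc34)=C2C#N)cc1` differs from compound 2 in one place, (methyl in place of dimethylamino on an aromatic carbon). Going by the values given here, the one measured step that touches the same position is the exchange of fluoro for dimethylamino, which moved this assay a number 1.9 percentage points lower from compound 1 to compound 2 (within the scatter). A substituent swap on this ring has thus not moved the read-out beyond the scatter, and compounds 1, 2 and 3 all sit in the same narrow band. On this basis the step from compound 2 to compound 4 is expected to be a number 1.5 percentage points higher from compound 2 to compound 4 (within the scatter), nothing beyond the scatter. Compound 4 is therefore estimated to give 22% in this assay, with a range from 14% to 30%.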

Compound 4, a percentage reported as activity, at one concentration (the size of the read-out at that concentration, not a potency): 6.2%
Beside the measured number, compound 4's estimate is 15.8 percentage points above it; measured number below the stated range.
By their numbers in this assay, from the lowest: compound 4; then compounds 2, 1 and 3 (each within the scatter of the next).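

In this assay this position proves not to be indifferent to its substituent: methyl in place of dimethylamino gives a number 14.3 percentage points lower from compound 2 to compound 4 (beyond the scatter) and methyl in place of fluoro gives a number 16.2 percentage points lower from compound 1 to compound 4 (beyond the scatter) on the same aromatic carbon. The earlier exchange of fluoro for dimethylamino, a number 1.9 percentage points lower from compound 1 to compound 2 (within the scatter) and so no real change, had made the position look tolerant, whereas fluoro and dimethylamino now stand together apart from methyl. Nothing available here explains why methyl behaves differently from the other two groups.

The compounds shown leave open whether the loss belongs to methyl alone or extends to longer chains such as ethyl or propyl. They also leave open where groups such as methoxy, chloro or a carboxylic acid would fall at this position.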